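An Azetidine Ether in Place of Cyclopropyl

The compounds below may be only part of what the source reports. "The series", "measured", "known", "first", "only" and "open" are said of these compounds alone.

Compound 1 `COc1cc(-c2nnc3c(OC(C)C)cc(-c4ccc5[nH]ccc5c4)cn23)cc(OC)c1OC` gives 261 nM
Compound 2 `COc1cc(-c2nnc3c(OCC(F)(F)F)cc(-c4ccc5[nH]ccc5c4)cn23)cc(OC)c1OC` gives 348 nM
Compound 3 `COc1cc(-c2nnc3c(OC4CC4)cc(-c4ccc5[nH]ccc5c4)cn23)cc(OC)c1OC` gives 119 nM

These values come from a functional assay on HeLa cells (Homo sapiens) for antiproliferative activity, read by MTT assay, with a stated time of 48 h (on this read-out higher numbers stand for weaker inhibition and lower numbers for stronger inhibition), and the three compounds differ only in the group on an oxygen on an aromatic ring. Compound 3 stands lowest of the three (119 nM), and its steps to both others lie beyond the scatter.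

The next structure is compound 4 `COc1cc(-c2nnc3c(OC4CN(C(C)(C)C)C4)cc(-c4ccc5[nH]ccc5c4)cn23)cc(OC)c1OC`, which has 1-(tert-butyl)azetidin-3-yl in place of cyclopropyl on an oxygen on an aromatic ring. Three measured steps at this place bear on the change. Two were modest (a 2.2-fold lower number from compound 1 to compound 3 (0.34 log units; beyond the scatter); a 2.9-fold lower number from compound 2 to compound 3 (0.47 log units; beyond the scatter)) and one stayed within the scatter (a 1.3-fold higher number from compound 1 to compound 2 (0.12 log units; within the scatter)). Among the measured compounds shown here, none of the measured groups holds a nitrogen, so the entering group lies outside what these data cover, and the expectation is loose. Of the measured groups, cyclopropyl gives the lowest number, while compound 1 gives 261 nM and compound 2 gives 348 nM, so a modest rise rather than a fall is expected in this assay. The expected step is of similar size to those measured (a 2.5-fold higher number from compound 3 to compound 4 (0.40 log units; beyond the scatter)). For compound 4 the estimated value is 300 nM (expected range 90 nM to 1000 nM).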

Compound 4, half-maximal inhibitory concentration: > 10000 nM
Compound 4 was reported as a limit; the forecaster's own chance of this, stated with the estimate: 3%; middle value at least 33-fold (1.52 log units) away from the limit.
By their numbers in this assay, from the lowest: compound 3; then compounds 1 and 2 (each within the scatter of the next). At a limit, above all of these: compound 4.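

In this assay compound 4 is reported only as a limit, not as a number: the limit of > 10000 nM in this assay, at which 1 of the 4 values shown sits.
Read against that limit, the place on an oxygen on an aromatic ring proves far less forgiving than the earlier compounds suggested: 1-(tert-butyl)azetidin-3-yl gives an at least 84-fold higher number from compound 3 to compound 4 (1.92 log units; beyond the scatter), as well as an at least 28-fold higher number from compound 2 to compound 4 (1.45 log units; beyond the scatter) and an at least 38-fold higher number from compound 1 to compound 4 (1.58 log units; beyond the scatter), each much larger than any step among isopropyl, 2,2,2-trifluoroethyl and cyclopropyl. This one change brings in a nitrogen, a four-membered ring and a tert-butyl group together, so the data cannot say which of these goes with the loss.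

The compounds shown leave open whether a cyclobutyl group, which keeps an all-carbon ring, would stay close to the earlier compounds, and whether an azetidine carrying a methyl group on its nitrogen, or a hydrogen there, would behave like compound 4. They also leave open how an oxetane, with oxygen in the four-membered ring in place of nitrogen, or an open-chain amine on the same oxygen would fare.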